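Trifluoromethyl for chloro on the carbonyl-bearing ring

The source may hold more compounds than are shown below. What is called first, only, known or untested is meant among the compounds shown, and "the series" means these compounds.

Measured so far in a functional assay on A375P cells (Homo sapiens) for antiproliferative activity, read by MTT assay, with a stated time of 48 h; a higher number here means a weaker inhibitor, a lower number a stronger inhibitor:
compound 1, `Nc1cccc2c(-c3cccc(NC(=O)c4ccc(C(F)(F)F)cc4C(F)(F)F)c3)ccnc12` — compound 1 gives > 20000 nM, a limit of the assay
compound 2, `CC(=O)Nc1cccc2c(-c3cccc(NC(=O)c4cccc(C(F)(F)F)c4)c3)ccnc12` — compound 2 gives 8000 nM
compound 3, `CC(=O)Nc1cccc2c(-c3cccc(NC(=O)c4ccc(Cl)cc4C(F)(F)F)c3)ccnc12` — compound 3 gives > 20000 nM, again a limit of the assay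

Compound 3 thus stands at the limit of this assay, and no number is known for it. Compound 2 is the only one of the three with a number, and the step of an at least 2.5-fold higher number from compound 2 to compound 3 (0.39 log units; beyond the scatter) shows that swapping in the 4-chloro-2-(trifluoromethyl)phenyl group pushed the value past the limit. Compound 1, which carries the acyl group that compound 4 will carry but with a free amino group on the shared core, also sits at that limit; the relevant observation is the limit of > 20000 nM in this assay, at which 2 of the 3 values shown sit.

Compound 4, `CC(=O)Nc1cccc2c(-c3cccc(NC(=O)c4ccc(C(F)(F)F)cc4C(F)(F)F)c3)ccnc12`, differs from compound 3 by trifluoromethyl in place of chloro on an aromatic carbon. Among the measured compounds shown here, the only measured step on this ring, from compound 2 to compound 3, was at least modest and toward a weaker inhibitor, and the value of compound 1 points the same way. Compound 4 is therefore expected to stay at or past the limit, with an estimated step that the limit leaves unreadable from compound 3 to compound 4. For compound 4 the estimate in this assay is 35000 nM, between 12000 nM and 120000 nM.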

Compound 4, half-maximal inhibitory concentration: 10100 nM
Beside the measured number, compound 4's estimate is 3.5-fold (0.54 log units) above it; measured number outside the range, below it.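

Trifluoromethyl in place of chloro on this aromatic carbon, para to a large group and meta to a trifluoromethyl group, gives a measurable value in this assay, with an at least 1.9-fold lower number from compound 3 to compound 4 (0.29 log units; that floor lies within the scatter). Acetyl in place of hydrogen on the nitrogen of the shared core also goes with a measurable value in this assay, with an at least 1.9-fold lower number from compound 1 to compound 4 (0.29 log units; that floor lies within the scatter), so the acyl group of compound 1 does not by itself keep a compound at the limit. Both steps start from a limit, so their true sizes stay unknown and the direction of neither is established beyond the scatter: the limit of > 20000 nM in this assay, at which 2 of the 4 values shown sit.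

The compounds shown leave open whether a methyl, a methoxy or a nitrile on this aromatic carbon would also give a measurable value in this assay, or whether that outcome is tied to trifluoromethyl. They also leave open how a longer acyl chain, or a carboxylic acid in place of the acetyl group, on the nitrogen of the shared core would compare with compound 4.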